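The compounds below may be only part of what the source reports. "The series", "measured", "known", "first", "only" and "open" are said of these compounds alone.

Of the compounds shown here, three that share one core have been measured in a functional assay on HEK293 cells for agonist activity at Glucose-dependent insulinotropic receptor (Mus musculus), read by fluorescence and cAMP accumulation, with a stated time of 30 min; a lower number here means that less compound is needed, a higher number that more compound is needed for the effect. Compound 1 `Cc1c(Nc2ccc(C#N)cc2Cl)ncnc1OC1C2COCC1CN(C(=O)OC1(C)CC1)C2` gives 33 nM. Compound 2 `COc1c(Nc2ccc(C#N)cc2Cl)ncnc1OC1C2COCC1CN(C(=O)OC1(C)CC1)C2` gives 43 nM. Compound 3 `CC1(OC(=O)N2CC3COCC(C2)C3Oc2cc(Nc3ccc(C#N)cc3Cl)ncn2)CC1` gives 254 nM. Compound 2 therefore stands close to compound 1, since the step of a 1.3-fold higher number from compound 1 to compound 2 (0.11 log units; within the scatter) is within the scatter, and clearly apart from compound 3, since the step of a 5.9-fold higher number from compound 2 to compound 3 (0.77 log units; beyond the scatter) is beyond it; the step of a 7.7-fold higher number from compound 1 to compound 3 (0.89 log units; beyond the scatter) tells the same story from the other end.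

Compound 4 `COc1c(Nc2ccc(C#N)cc2F)ncnc1OC1C2COCC1CN(C(=O)OC1(C)CC1)C2` has not yet been measured. It differs from compound 2 in one place: fluoro in place of chloro on an aromatic carbon. For the measured compounds named here, none of the measured steps touches this position; all three concern the group on an aromatic carbon of the core, where methyl and methoxy give close numbers and hydrogen gives a higher one. The measured steps thus offer no direct guide to exchanging one halogen for another on the aniline ring. With nothing pointing to a large shift, the step expected is a 1.5-fold higher number from compound 2 to compound 4 (0.18 log units; within the scatter), a change that may well stay inside the scatter. Compound 4 is accordingly estimated at 65 nM, with a range from 25 nM to 170 nM.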

Compound 4, half-maximal effective concentration: 47 nM
The estimate for compound 4 lay 1.4-fold (0.14 log units) above the measured number; the measured number falls inside the stated range.
By their numbers in this assay, from the lowest: compounds 1, 2 and 4 (each within the scatter of the next); then compound 3.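

Until now, nothing had been seen at this site, a position on the six-membered aromatic ring of carbon only that is ortho to a large group and meta to a cyano group. In this assay, going from 2-chloro-4-cyanophenyl to 4-cyano-2-fluorophenyl gives a 1.1-fold higher number from compound 2 to compound 4 (0.04 log units; within the scatter) and so leaves the number unchanged within the scatter, which means that these two halogens cannot be told apart here, unlike the hydrogen and methoxy groups compared on the core. Nothing available explains why this exchange is tolerated.

The compounds shown leave open whether a group other than a halogen, such as an amine or a trifluoromethyl group, would be tolerated at this position. Going by these compounds, it also remains open whether the fluoro-for-chloro exchange would read the same with methyl on the core, as in compound 1, or with hydrogen, as in compound 3.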